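Methoxy in Place of Isopropyl on the Aromatic Carbon

The source may hold more compounds than are shown below. What is called first, only, known or untested is meant among the compounds shown, and "the series" means these compounds.

Three measured compounds share one core and differ only in the group on one aromatic carbon. Compound 1 `CCc1nc2c(C)cc(C)nc2n1Cc1ccc(OC(C(=O)O)c2ccccc2)c(Cl)c1` carries a chloro there and in an assay on Midbrain with Type-2 angiotensin II receptor (Rattus norvegicus) as the target (a lower number here means a stronger inhibitor, a higher number a weaker inhibitor), compound 1 gives 720 nM. Compound 2 `CCc1nc2c(C)cc(C)nc2n1Cc1ccc(OC(C(=O)O)c2ccccc2)c(C)c1` carries a methyl, and in this assay compound 2 gives 940 nM; the difference a 1.3-fold higher number from compound 1 to compound 2 (0.12 log units; within the scatter) lies within the scatter. Compound 3 `CCc1nc2c(C)cc(C)nc2n1Cc1ccc(OC(C(=O)O)c2ccccc2)c(C(C)C)c1` carries an isopropyl, and in this assay compound 3 gives 3300 nM, the highest number of the three, beyond the scatter from both others.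

Compound 4 `CCc1nc2c(C)cc(C)nc2n1Cc1ccc(OC(C(=O)O)c2ccccc2)c(OC)c1` differs from compound 3 in one place: methoxy in place of isopropyl on an aromatic carbon. Within the data shown here, the steps that bear on this are the two that led to the isopropyl of compound 3, a 4.6-fold higher number from compound 1 to compound 3 (0.66 log units; beyond the scatter) and a 3.5-fold higher number from compound 2 to compound 3 (0.55 log units; beyond the scatter), both modest and both toward a higher number. The methoxy that enters is, like the chloro of compound 1 and the methyl of compound 2, a group other than the isopropyl, so compound 4 is expected to move back toward those two because a 3.5-fold higher number from compound 2 to compound 3 (0.55 log units; beyond the scatter) was the cost of the isopropyl. The estimated step is a 3.3-fold lower number from compound 3 to compound 4 (0.52 log units; beyond the scatter). For compound 4 in this assay the expected value is 1000 nM, with a range from 400 nM to 2500 nM.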

Compound 4, half-maximal inhibitory concentration: 2900 nM
Compound 4: the middle estimate sits 2.9-fold (0.46 log units) below what was measured; the measured number lies above the stated range.
By their numbers in this assay, from the lowest: compounds 1 and 2 (each within the scatter of the next); then compounds 4 and 3 (each within the scatter of the next).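

Replacing the isopropyl with a methoxy gives a 1.1-fold lower number from compound 3 to compound 4 (0.06 log units; within the scatter) in this assay, so the methoxy, which carries a hydrogen-bond acceptor where the isopropyl has none, stands with the isopropyl and not with the chloro or the methyl. The gap to the other two groups is now seen with a second group, through a 3.1-fold higher number from compound 2 to compound 4 (0.49 log units; beyond the scatter) and a 4.0-fold higher number from compound 1 to compound 4 (0.61 log units; beyond the scatter), so in these four compounds the higher numbers are not confined to the isopropyl, and the four fall into two pairs, the chloro with the methyl and the methoxy with the isopropyl. Nothing measured on these compounds accounts for why the methoxy groups with the isopropyl rather than with the methyl, the other group that differs from the chloro at this carbon, and no outside data on this change are at hand.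

What the compounds shown leave open is whether the two pairs reflect a wider rule at this carbon, which a fluoro, a hydroxyl, an amine or an ethoxy there would test. They also leave open whether a plain hydrogen on this carbon would read with the chloro and the methyl or with the methoxy and the isopropyl.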